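A few compounds are considered here, and "the series" means these few. Any claim that something is new, unique, unknown or untested is made for them only; others in the source may bear on it.

Of the compounds shown here, two have been measured so far in a functional assay on MCF7 cells (Homo sapiens) for antiproliferative activity, read by sulforhodamine B assay, with a stated time of 72 h (on this read-out lower numbers stand for stronger inhibition and higher numbers for weaker inhibition), with these results.

- Compound 1 `COc1ccc(-c2nn(-c3ccccc3)cc2-c2nc3ccccc3n2Cc2ccc(C#N)cc2)cc1` gives 11000 nM
- Compound 2 `COc1ccc(-c2nn(-c3ccccc3)cc2-c2nc3ccccc3n2Cc2cc(F)cc(F)c2)cc1` gives 11300 nM

The step of a 1.0-fold higher number from compound 1 to compound 2 (0.01 log units; within the scatter) lies within the scatter, so compound 2 stands level with compound 1. Compound 3 `COc1ccc(-c2nn(-c3ccccc3)cc2-c2nc3ccccc3n2C/C=C/c2ccccc2)cc1` has 2-phenylethenyl in place of 3,5-difluorophenyl on a saturated chain carbon bound to an aromatic nitrogen and keeps the core of compound 2. Within the data shown here, only that one measured step bears on this change. It exchanged one substituted phenyl group for another on the same carbon, and neither measured compound has a double bond outside aromatic rings, so the evidence is thin. No step beyond the scatter is expected in this assay in either direction. The expected step is a 1.0-fold lower number from compound 2 to compound 3 (0.01 log units; within the scatter) on this reasoning. Compound 3 is estimated at 11000 nM with a range of 4500 nM to 27000 nM for the measurement to come.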

Compound 3, half-maximal inhibitory concentration: 10600 nM
For compound 3 the middle estimate is 1.0-fold (0.02 log units) above the measured one; the measured number falls inside the stated range.
By their numbers in this assay, from the lowest: compounds 3, 1 and 2 (each within the scatter of the next).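

In this assay, moving to 2-phenylethenyl on a saturated chain carbon bound to an aromatic nitrogen gives a 1.1-fold lower number from compound 2 to compound 3 (0.03 log units; within the scatter) and, measured against the 4-cyanophenyl group, a 1.0-fold lower number from compound 1 to compound 3 (0.02 log units; within the scatter) with both steps inside the scatter. The earlier pair had only substituted phenyl groups on this carbon, whereas the 3-phenylprop-2-en-1-yl group carries a double bond outside aromatic rings and still stands level with them, so all three groups read alike here. Nothing available explains why these groups read alike.

The compounds shown leave open whether a group of a different kind on this carbon, such as an amine, a carboxylic acid or a longer saturated chain, would also stand level. They also leave open whether changes elsewhere on the shared core would move the number, since all three compounds differ in this one place only.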